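A Methyl Added Ortho on the Phenyl Ring of Compound 1

The compounds below may be only part of what the source reports. "The series", "measured", "known", "first", "only" and "open" are said of these compounds alone.

Compound 1 `C/C(=C\c1cc(-c2ccccc2)cs1)C(N)=O` was tested for cytotoxicity in a functional assay on BGC-823 cells (Homo sapiens) for cytotoxicity, read by CCK-8 assay, with a stated time of 24 h; on this read-out higher numbers stand for weaker inhibition and lower numbers for stronger inhibition. In this assay compound 1 gives > 50000 nM, which is a limit of the assay rather than a measured number. Compound 2 `C/C(=C\c1cc(-c2ccc(C)cc2)cs1)C(N)=O` carries a methyl in place of hydrogen on an aromatic carbon. In this assay compound 2 gives > 50000 nM, again a limit and not a number. The step that the two limits leave unreadable from compound 1 to compound 2 can thus not be read. Compound 1 stands at the limit of > 50000 nM in this assay, at which 2 of the 2 values shown sit, with no measured number to anchor it. Compound 3 `C/C(=C\c1cc(-c2ccccc2C)cs1)C(N)=O` differs from compound 1 by methyl in place of hydrogen on an aromatic carbon. For the measured compounds named here, the only related step, from compound 1 to compound 2, had no readable size, so no direction beyond the scatter can be expected. The step that the limit leaves unreadable from compound 1 to compound 3 is therefore estimated as no visible change. Compound 3 is expected to give about 80000 nM, between 30000 nM and 200000 nM, most likely again only as a limit.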

Compound 3, half-maximal inhibitory concentration: > 50000 nM
Compound 3: only a limit was reported (the forecaster's own chance of this, stated with the estimate: 85%); the middle value lies beyond the limit too.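

Compound 3 also gives only a limit, not a number, so the step from compound 1 to compound 3 cannot be read, and all three compounds sit at the same limit: the limit of > 50000 nM in this assay, at which 3 of the 3 values shown sit.

The compounds shown leave open whether methyl in place of hydrogen on the aromatic ring changes cytotoxicity at all, and how strong compound 1, compound 2 and compound 3 really are.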